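Dipropylamino in place of pyrrolidin-1-yl: compound 3 to compound 4

The compounds below may be only part of what the source reports. "The series", "measured", "known", "first", "only" and "open" are said of these compounds alone.

The series shares one core and varies the amine on a double-bonded ring carbon. In a functional assay on ECa-109 cells for inhibition, with ECa-109 cell line (Homo sapiens) as the target, read by sulforhodamine B assay (a higher number here means a weaker inhibitor, a lower number a stronger inhibitor), compound 1 `O=C1C(NC2CCCC2)=CC(=O)c2c1nc1n2[C@H]2OC[C@@H](O)[C@H]2OC1` gives only a limit, > 16000 nM. Compound 2 `Cc1ccc(NC2=CC(=O)c3c(nc4n3[C@H]3OC[C@@H](O)[C@H]3OC4)C2=O)cc1` also gives only a limit, > 4000 nM. Compound 3 `O=C1C(N2CCCC2)=CC(=O)c2c1nc1n2[C@H]2OC[C@@H](O)[C@H]2OC1` likewise gives only a limit, > 16000 nM. Compound 3 therefore stands at the limit of > 16000 nM in this assay, at which 2 of the 3 values shown sit. The remaining value is the limit of > 4000 nM in this assay, at which 1 of the 3 values shown sits.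

Compound 4 `CCCN(CCC)C1=CC(=O)c2c(nc3n2[C@H]2OC[C@@H](O)[C@H]2OC3)C1=O` carries dipropylamino in place of pyrrolidin-1-yl on a double-bonded ring carbon.

Two measured changes at this place bear on it: a step that the two limits leave unreadable from compound 1 to compound 3 and a step that the two limits leave unreadable from compound 2 to compound 3. Neither gives a size or a direction for this assay, so no change beyond the scatter is expected, and another reading as a limit is likely. The expected outcome is a number no higher from compound 3 to compound 4 (the limit leaves the size open). Compound 4 is estimated at 16000 nM, with an expected range of 6000 nM to 45000 nM.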

Compound 4, half-maximal inhibitory concentration: > 16000 nM
Compound 4: only a limit was reported; the forecaster's own chance of this, stated with the estimate: 75%; the middle value lies on the limit itself.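

In this assay compound 4 gives only a limit, > 16000 nM. Within the data shown here, compound 1, compound 2 and compound 3 also give only limits, so no step to compound 4 can be read. The compounds shown leave open whether any of these amines on the double-bonded ring carbon differs from another in this assay, and by how much.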